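This account rests on a few compounds, and the source may have more. Where it says the series, first, only, none or still open, it means among the compounds named here.

Compound 3 `CC(=O)N[C@@H]1CCC[C@H](C(=O)Nc2cc(-c3cnn4c3CN(C)CC4)c(Cl)cn2)C1` gives 2.1 in a physicochemical assay for lipophilicity, using the shake flask method, measured as octanol-water partition, at pH 7.4 (on this read-out higher numbers stand for higher lipophilicity and lower numbers for lower lipophilicity), and stands lowest of the three measured compounds, under compound 1 `CC(=O)N[C@@H]1CCC[C@H](C(=O)Nc2cc(-c3cnn(C)c3C)c(Cl)cn2)C1` at 2.6 and compound 2 `CC(=O)N[C@@H]1CCC[C@H](C(=O)Nc2cc(-c3cnn4c3CCCCC4)c(Cl)cn2)C1` at 3.6. Compound 4 `CC(=O)N[C@@H]1CCC[C@H](C(=O)Nc2cc(-c3cnc4n3CC(C)(C)C4)c(Cl)cn2)C1` differs from compound 3 as follows: a group of 10 heavy atoms (8 carbon, 2 nitrogen; one five-membered non-aromatic ring with 1 hetero atom, one five-membered aromatic ring with 2 hetero atoms) in place of a group of 10 heavy atoms (7 carbon, 3 nitrogen; one five-membered aromatic ring with 2 hetero atoms, one six-membered non-aromatic ring with 2 hetero atoms), on an aromatic carbon. Going by the values given here, the steps that bear on this are a number 1.00 log units higher from compound 1 to compound 2 (beyond the scatter) and a number 0.50 log units lower from compound 1 to compound 3 (beyond the scatter), both modest, and a number 1.50 log units lower from compound 2 to compound 3 (beyond the scatter), which is large. That last step also exchanges groups of 10 heavy atoms, with the group holding 3 nitrogen atoms giving the lower number. Among the compounds with values here, no measured compound carries the entering group, so a modest rise rather than a large one is expected in this assay. The expected size is a number 0.70 log units higher from compound 3 to compound 4 (beyond the scatter). For compound 4 the estimated value is 2.8, within an expected range of 2.2 to 3.4.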

Compound 4, distribution coefficient: 3.6
Compound 4: middle estimate off by 0.80 log units, on the low side; measured number outside the range, above it.
By their numbers in this assay, from the lowest: compound 3; then compound 1; then compounds 2 and 4 (each within the scatter of the next).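

On an aromatic carbon opposite the ring nitrogen, the exchange between these two groups of 10 heavy atoms gives a number 1.50 log units higher from compound 3 to compound 4 (beyond the scatter) in this assay and the heavy-atom count alone therefore does not set the number. The group entering here, with 2 nitrogen atoms, gives no change at the digits printed from compound 2 to compound 4 (within the scatter) against the other group with 2 nitrogen atoms and a number 1.00 log units higher from compound 1 to compound 4 (beyond the scatter) against the group of 7 heavy atoms. Nothing measured here accounts for these steps. Going by these compounds, whether the number of nitrogen atoms or the ring arrangement governs the steps remains open, as does the reading of a group carrying a carboxylic acid at this position.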